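A Mirror Image Put to the Test

A few compounds are considered here, and "the series" means these few. Any claim that something is new, unique, unknown or untested is made for them only; others in the source may bear on it.

Of the compounds shown here, two have so far been measured in an assay on membranes from liver for displacement of a labelled ligand from Sigma intracellular receptor 2 (Rattus norvegicus), read by scintillation counting; a lower number here means a stronger inhibitor, a higher number a weaker inhibitor. Compound 1, `CN(C)CC[C@H]1CCC[C@@H](c2ccccc2)O1`, gives 4000 nM in this assay. Among the measured compounds shown here, compound 2, `c1ccc([C@H]2CCC[C@@H](CCN3CCCC3)O2)cc1`, gives 115 nM in this assay, the lowest of the two numbers; its only neighbour is compound 1, whose number is far higher, a gap well beyond the usual scatter. Compound 3, `c1ccc([C@@H]2CCC[C@H](CCN3CCCC3)O2)cc1`, is the next candidate. Compared with compound 2, (the two compounds have the same atoms and bonds and differ only in configuration as drawn: 2 of 2 stereo elements differ (all stereocentres are inverted: mirror images); a stereocentre at a saturated ring carbon is drawn R in compound 2 and S in compound 3; a stereocentre at a saturated ring carbon is drawn S in compound 2 and R in compound 3). In plain words, compound 3 is the mirror image of compound 2, with both ring stereocentres inverted and nothing else altered. For the measured compounds named here, no measured pair here shows what such an inversion does, so the expectation cannot lean on any step already seen and must remain cautious. A step toward a higher number is expected for compound 3, of moderate size, as a 3.5-fold higher number from compound 2 to compound 3 (0.54 log units; beyond the scatter) expresses. Compound 3 is therefore estimated at 400 nM in this assay, with a range from 100 nM to 2000 nM, the wide span reflecting that nothing measured anchors this particular change.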

Compound 3, inhibition constant: 170 nM
Estimate against measurement, compound 3: 2.4-fold (0.37 log units) above; the range from low to high includes it.
By their numbers in this assay, from the lowest: compounds 2 and 3 (each within the scatter of the next); then compound 1.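

Inverting both ring stereocentres gives a 1.5-fold higher number from compound 2 to compound 3 (0.17 log units; within the scatter) in this assay, so this read-out does not separate the two mirror images, and the hand of the molecule as a whole shows no effect that can be told from ordinary repeat scatter. This is an unusually clean comparison, since no atom or bond changes and configuration is the only variable: the fact that compounds 2 and 3 differ only in the configuration as drawn. The amine on the chain tells a different story: pyrrolidin-1-yl in place of dimethylamino gives a 24-fold lower number from compound 1 to compound 3 (1.37 log units; beyond the scatter), so among these three compounds the large difference goes with the amine and the inversion of both stereocentres leaves no mark beyond the scatter.

Going by these compounds, whether a piperidine ring, a morpholine ring or a longer chain between the core and the amine would keep numbers as low as those of compound 2 and compound 3 remains open. Also open, on these data alone, are what inverting just one of the two stereocentres would do, and whether the mirror image of compound 1 would match it as closely as compound 3 matches compound 2.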